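Trading the Pendant Phenyl for Fluoro on a Shared Core

The source may hold more compounds than are shown below. What is called first, only, known or untested is meant among the compounds shown, and "the series" means these compounds.

Three carbamates built on one shared core have been measured. In an assay on HEK293 cells for inhibition of acid ceramidase (Homo sapiens), with a stated time of 10 min (on this read-out lower numbers stand for stronger inhibition and higher numbers for weaker inhibition), compound 1 `O=C(NCCCCc1ccccc1)n1c(=O)oc2cc(-c3ccc(F)cc3)ccc21` gives 79 nM, compound 2 `O=C(NCCCCc1ccccc1)n1c(=O)oc2ccc(-c3ccccc3)cc21` gives 42 nM, and compound 3 `COc1ccc(-c2ccc3c(c2)oc(=O)n3C(=O)NCCCCc2ccccc2)cc1` gives 67 nM. Compound 2 stands at the low end of these three numbers, but its gaps to compound 3 and to compound 1 both lie within the scatter, so no ranking follows. For the measured compounds named here, the one single-point step measured, a 1.2-fold lower number from compound 1 to compound 3 (0.07 log units; within the scatter), shows that swapping the substituent on the pendant phenyl leaves the number where it was. Compound 4 `O=C(NCCCCc1ccccc1)n1c(=O)oc2ccc(F)cc21` differs from compound 2 by fluoro in place of phenyl on an aromatic carbon. Going by the values given here, no measured step removes that phenyl altogether, so the bearing of the data is slight. A weaker result is expected, a step of a 3.6-fold higher number from compound 2 to compound 4 (0.55 log units; beyond the scatter) in this assay. Compound 4 is therefore estimated at 150 nM, between 40 nM and 600 nM.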

Compound 4, half-maximal inhibitory concentration: 12 nM
For compound 4 the middle estimate is 13-fold (1.10 log units) above the measured one, and the stated range ends above it.
By their numbers in this assay, from the lowest: compound 4; then compounds 2, 3 and 1 (each within the scatter of the next).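

Fluoro in place of phenyl gives a 3.5-fold lower number from compound 2 to compound 4 (0.54 log units; beyond the scatter) in this assay, so at this position the phenyl is not needed for a low number. The earlier step only changed a substituent on a pendant phenyl, whereas this one removes the whole ring and leaves a single fluorine on the aromatic carbon. No evidence at hand accounts for this step.

The compounds shown leave open how chloro, methyl or an amine on this same aromatic carbon would compare with fluoro. They also leave open whether hydrogen alone would serve as well.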